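This account rests on a few compounds, and the source may have more. Where it says the series, first, only, none or still open, it means among the compounds named here.

Measured in an ADME assay on GES1 cells (Homo sapiens) for inhibition, read by MTT assay, with a stated time of 72 h; on this read-out higher numbers stand for weaker inhibition and lower numbers for stronger inhibition:
Compound 1 `Cc1cc(Nc2ccn(Cc3cccc4ccccc34)n2)n2nc(SCc3ccc(Br)cc3)nc2n1` gives 30000 nM.
Compound 2 `Cc1cc(Nc2cc(-c3ccccc3)[nH]n2)n2nc(SCc3c(Cl)cccc3Cl)nc2n1` gives 39600 nM.
Compound 3 `CCCCCc1c(C)nc2nc(SCc3ccc(Cl)cc3)nn2c1Nc1cc(-c2ccccc2)[nH]n1` reaches only the limit of > 50000 nM, which is not a number.

Compound 2 holds the highest of the two numbers given, and compound 1 sits a short way lower, within the scatter of this assay, so no order between the two is claimed. Compound 3 stands at the limit (the limit of > 50000 nM in this assay, at which 1 of the 3 values shown sits). Compound 4 `Cc1cc(Nc2cc(-c3ccccc3)[nH]n2)n2nc(SCc3ccc(F)cc3)nc2n1` is not yet measured; against compound 2 the change is 4-fluorophenyl in place of 2,6-dichlorophenyl on a saturated chain carbon bound to a sulfur. Among the compounds with values here, no measured pair differs in one place only, so no step size is known from the data. The step from compound 2 to compound 4 in this assay is estimated as a 1.0-fold higher number from compound 2 to compound 4 (0.00 log units; within the scatter), none beyond the scatter. Compound 4 is expected near 40000 nM, between 15000 nM and 50000 nM, with a fair chance that only a limit is reported.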

Compound 4, half-maximal inhibitory concentration: 35500 nM
Beside the measured number, compound 4's estimate is 1.1-fold (0.05 log units) above it; the measured number falls inside the stated range.
By their numbers in this assay, from the lowest: compounds 1, 4 and 2 (each within the scatter of the next). At a limit, above all of these: compound 3.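

In this assay, within the data shown here, the one step read at this position is a 1.1-fold lower number from compound 2 to compound 4 (0.05 log units; within the scatter), so exchanging 2,6-dichlorophenyl for 4-fluorophenyl on a saturated chain carbon bound to a sulfur produces no difference beyond the scatter. At this position, the read-out therefore does not separate these two substituted phenyl groups. Compound 3 stands at a limit, which is not a number: the limit of > 50000 nM in this assay, at which 1 of the 4 values shown sits.

From the compounds shown here alone, whether a step beyond the scatter can occur at this position remains open. A morpholine, a carboxylic acid or a longer alkyl chain in place of the phenyl group would test this.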